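Aryl swap on the amine nitrogen, compound 2 to compound 3

This account rests on a few compounds, and the source may have more. Where it says the series, first, only, none or still open, it means among the compounds named here.

Measured so far:
compound 1, `COc1ccc(C(F)(F)F)cc1Nc1cc(NC(=O)Nc2c(Cl)cccc2Cl)ncn1`: 68.7%
compound 2, `COc1cc(NC(=O)Nc2cc(Nc3ccc(OC)c(I)c3)ncn2)cc(OC)c1`: 61.7%

In a functional assay on HCC827 cells (Homo sapiens) for inhibition, read by MTT assay, with a stated time of 48 h, tested at 10 uM (on this read-out lower numbers stand for less inhibition and higher numbers for more inhibition at the one concentration tested (going by the name of the read-out)), compound 1 gives 68.7% and compound 2 gives 61.7%. Compound 2 carries the lower of the two numbers, but its gap to compound 1 lies within the scatter, so no order between the two is claimed.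

Compound 3 `COc1cc(NC(=O)Nc2cc(Nc3cc(F)ccc3OC)ncn2)cc(OC)c1` differs from compound 2 by 5-fluoro-2-methoxyphenyl in place of 3-iodo-4-methoxyphenyl on a nitrogen on an aromatic ring. Going by the values given here, no step between measured compounds is available to size this change, and the two measured numbers sit within the scatter of each other. The step is therefore expected to be a number 1.7 percentage points lower from compound 2 to compound 3 (within the scatter), none beyond the scatter. Compound 3 is expected to give about 60%, within 40% to 78%.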

Compound 3, a percentage reported as inhibition, at one concentration (the size of the read-out at that concentration, not a potency): 59%
Beside the measured number, compound 3's estimate is 1 percentage points above it; low and high end bracket the measured number.
By their numbers in this assay, from the lowest: compounds 3, 2 and 1 (each within the scatter of the next).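

In this assay, going by these compounds alone, 5-fluoro-2-methoxyphenyl in place of 3-iodo-4-methoxyphenyl on a nitrogen on an aromatic ring gives the first measured step at this position (a number 2.7 percentage points lower from compound 2 to compound 3 (within the scatter)). This exchange of one aryl group for the other, with iodine gone and fluorine present, therefore gives no difference that can be told from the scatter. No measured evidence bears on this result.

From the compounds shown here alone, whether an amine or a carboxylic acid on this aryl ring would give a step beyond the scatter stays open. One step also cannot show how this exchange behaves with other groups on the shared core.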